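Trifluoromethyl added to the fluorophenyl arm of compound 1

This account rests on a few compounds, and the source may have more. Where it says the series, first, only, none or still open, it means among the compounds named here.

Compound 1 `CC1=C(/C=C/C(=O)/C=C/c2ccccc2F)C(C)(C)CCC1O` carries a 2-fluorophenyl arm on the shared core; in a functional assay on PC-3 cells (Homo sapiens) for cytotoxicity, read by MTT assay, with a stated time of 72 h (on this read-out lower numbers stand for stronger inhibition and higher numbers for weaker inhibition), compound 1 gives 10400 nM. Compound 2 `CC1=C(/C=C/C(=O)/C=C/c2ccc(F)cc2)C(C)(C)CCC1O` gives 6200 nM in this assay. The two cores differ by 2-fluorophenyl in place of 4-fluorophenyl on a double-bonded chain carbon bound to a double-bonded chain carbon, and the measured step is a 1.7-fold lower number from compound 1 to compound 2 (0.22 log units; within the scatter). Compound 3 `CC1=C(/C=C/C(=O)/C=C/c2ccc(F)c(C(F)(F)F)c2)C(C)(C)CCC1O` gives 7300 nM in this assay. The change from compound 2 to compound 3 is trifluoromethyl in place of hydrogen on an aromatic carbon, and it made a 1.2-fold higher number from compound 2 to compound 3 (0.07 log units; within the scatter). All three numbers lie within the scatter of one another, so no order among compounds 1, 2 and 3 is drawn.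

Compound 4 `CC1=C(/C=C/C(=O)/C=C/c2ccc(C(F)(F)F)cc2F)C(C)(C)CCC1O` is not yet measured. It differs from compound 1 by trifluoromethyl in place of hydrogen on an aromatic carbon. Among the compounds with values here, this is the same kind of change as the one from compound 2 to compound 3, but not the same: in compound 3 the entering group stands ortho to a fluoro group and meta to a large group, whereas in compound 4 it stands meta to a fluoro group and para to a large group. Within the data shown here, the only measured instance of this kind of change was a 1.2-fold higher number from compound 2 to compound 3 (0.07 log units; within the scatter), within the scatter, and there is no second precedent for the new surrounding.

The expected step is therefore a 1.2-fold higher number from compound 1 to compound 4 (0.06 log units; within the scatter), a flat move. This expectation rests on a 1.2-fold higher number from compound 2 to compound 3 (0.07 log units; within the scatter) and on compound 1 standing at 10400 nM. Compound 4 is estimated at about 12000 nM in this assay, expected to fall between 6000 nM and 25000 nM.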

Compound 4, half-maximal inhibitory concentration: 4600 nM
The estimate for compound 4 lay 2.6-fold (0.42 log units) above the measured number, and the stated range ends above it.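

On the core of compound 1, trifluoromethyl in place of hydrogen on an aromatic carbon gives in this assay a 2.3-fold lower number from compound 1 to compound 4 (0.35 log units; beyond the scatter), a modest step, and the flat result on the core of compound 2 therefore does not carry over to this core as a fixed increment: the same change on two cores in this assay, a 1.2-fold higher number (0.07 log units; within the scatter) from compound 2 to compound 3 and a 2.3-fold lower number (0.35 log units; beyond the scatter) from compound 1 to compound 4, 2.7-fold (0.43 log units) apart, beyond the scatter of two such steps. This shows that, in this series, the outcome of adding trifluoromethyl depends on the compound that receives it, and that a step read on one fluorophenyl arm is a poor guide to the same change on another. It does not show what sets the gap, since the two pairs differ both in the arm that carries the change and in where the group enters, with the trifluoromethyl of compound 4 standing meta to a fluoro group and para to a large group, and two pairs give no general rule for the series.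

The compounds shown leave open whether a nitrile or a methoxy group entering at the place taken by trifluoromethyl in compound 4 would give a similar step. Also open, as far as these compounds go, is whether the step holds when the hydroxyl on the shared core gives way to an amine.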